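A few compounds are considered here, and "the series" means these few. Any claim that something is new, unique, unknown or untested is made for them only; others in the source may bear on it.

Measured compounds:
Compound 1, `CCC(C)(C)Cc1c[nH]c(CCc2ccc(-c3cccc(C#N)n3)cc2)n1`: 26 nM
Compound 2, `CCC(C)(C)Cc1c[nH]c(CCc2ccc(N3CCCCC3)cc2)n1`: 28 nM

In a functional assay on HEK293 cells for agonist activity at Bombesin receptor subtype-3 (Mus musculus), read by luminescence and calcium flux, with a stated time of 10 min (a lower number here means that less compound is needed, a higher number that more compound is needed for the effect), compound 2 gives 28 nM. This is the higher of the two numbers, but only by a 1.1-fold higher number from compound 1 to compound 2 (0.03 log units; within the scatter), so compound 2 and compound 1 are indistinguishable within the scatter. Compound 3, `CCC(C)(C)Cc1c[nH]c(CCc2ccc(-c3cccnc3C(=O)O)cc2)n1`, differs from compound 2 by 2-carboxypyridin-3-yl in place of piperidin-1-yl on an aromatic carbon. Going by the values given here, the one measured step that bears on this position is the one from compound 1 to compound 2, where an aromatic heterocycle and piperidin-1-yl gave a 1.1-fold higher number from compound 1 to compound 2 (0.03 log units; within the scatter). Among the compounds with values here, that step shows the position tolerates exchange of an aromatic ring for a saturated one, but no measured compound carries a carboxylic acid, so the effect of the entering group is not covered by the data. Compound 3 is therefore expected to give 60 nM in this assay, within 15 nM to 300 nM, a step of a 2.1-fold higher number from compound 2 to compound 3 (0.33 log units; beyond the scatter) that leans toward a higher number only because of the uncertainty not covered by a 1.1-fold higher number from compound 1 to compound 2 (0.03 log units; within the scatter).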

Compound 3, half-maximal effective concentration: 14 nM
Beside the measured number, compound 3's estimate is 4.3-fold (0.63 log units) above it, and the stated range ends above it.
By their numbers in this assay, from the lowest: compounds 3, 1 and 2 (each within the scatter of the next).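

In this assay, going by these compounds alone, the position on an aromatic carbon para to a large group also admits 2-carboxypyridin-3-yl, the first group here to carry a carboxylic acid. The step of a 2.0-fold lower number from compound 2 to compound 3 (0.30 log units; within the scatter) replaces piperidin-1-yl, and the step of a 1.9-fold lower number from compound 1 to compound 3 (0.27 log units; within the scatter) replaces 6-cyanopyridin-2-yl, so all three groups now stand within the scatter of one another, although the entering group adds a hydrogen-bond donor that neither of the others has. Nothing at hand explains this tolerance. As far as these compounds go, whether the methyl ester or the primary amide of that acid would read the same remains open. So does whether an unsubstituted phenyl ring or a short chain ending in an amine would stay within the same range at this position.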